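The source may hold more compounds than are shown below. What is called first, only, known or untested is meant among the compounds shown, and "the series" means these compounds.

Working notes on the series.

The shared core is carried by compound 1 `COC(=O)Nc1nc2cc(C(=O)OC(C)C)ccc2[nH]1`, compound 2 `CCNC(=O)c1ccc2[nH]c(NC(=O)OC)nc2c1` and compound 3 `COC(=O)Nc1nc2cc(C(=O)OCC3CC3)ccc2[nH]1`. In a functional assay on L1210 cells (Mus musculus) for inhibition (a lower number here means a stronger inhibitor, a higher number a weaker inhibitor), compound 1 gives 700 nM, compound 2 gives 10000 nM and compound 3 gives 6900 nM. Compound 3 therefore stands second highest of the three numbers; its nearest neighbour is compound 2, within the scatter, while the step of a 9.9-fold higher number from compound 1 to compound 3 (0.99 log units; beyond the scatter) separates it clearly from compound 1. The remaining measured steps are a 14-fold higher number from compound 1 to compound 2 (1.15 log units; beyond the scatter) and a 1.4-fold lower number from compound 2 to compound 3 (0.16 log units; within the scatter), both concerning the group on the carbonyl carbon at the ester or amide end.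

Compound 4 `O=C(Nc1nc2cc(C(=O)OCC3CC3)ccc2[nH]1)OCC1CC1` differs from compound 3 by cyclopropyl in place of hydrogen on a saturated chain carbon bound to an oxygen next to a carbonyl group. Within the data shown here, no measured step alters this part of the core; the closest analogy in kind is the exchange of isopropyl for cyclopropylmethyl on an oxygen next to a carbonyl group, which gave the modest loss a 9.9-fold higher number from compound 1 to compound 3 (0.99 log units; beyond the scatter). Without a direct precedent, a small step is expected, if anything toward a higher number, and possibly none beyond the scatter. Compound 4 is estimated at 9000 nM in this assay, with a range from 3000 nM to 27000 nM. The expected step is a 1.3-fold higher number from compound 3 to compound 4 (0.12 log units; within the scatter).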

Compound 4, half-maximal inhibitory concentration: 2200 nM
Compound 4: middle estimate off by 4.1-fold (0.61 log units), on the high side; the measured number lies below the stated range.
By their numbers in this assay, from the lowest: compound 1; then compound 4; then compounds 3 and 2 (each within the scatter of the next).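

In this assay, among these compounds, the change from methoxycarbonyl to cyclopropylmethoxycarbonyl gives a 3.1-fold lower number from compound 3 to compound 4 (0.50 log units; beyond the scatter), the only measured step that alters this part of the shared core. The earlier compounds shown here varied only the group on the carbonyl carbon at the ester or amide end, so this result shows that the number also responds to cyclopropyl on a saturated chain carbon bound to an oxygen next to a carbonyl group, and that here the number falls. The cyclopropylmethyl group also entered at the ester end in a 9.9-fold higher number from compound 1 to compound 3 (0.99 log units; beyond the scatter), but that step replaces isopropyl rather than methyl, so the opposite directions of the two steps describe two different exchanges, and no measurement on these compounds offers an explanation for either.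

From the compounds shown here alone, whether the fall is specific to cyclopropyl remains open, since an ethyl group, a longer chain or a chain ending in an amine has no number at this place. Also open, going by these compounds, is whether the same exchange gives a step of similar size when the ester end carries the isopropyl group of compound 1.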